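A Second Hydroxymethyl Group Against MCF7 Cells

A few compounds are considered here, and "the series" means these few. Any claim that something is new, unique, unknown or untested is made for them only; others in the source may bear on it.

Two measured compounds frame the question. Compound 1 `Cc1c(CO)c(CO)c2n1[C@@H](c1ccccc1)SC2` gives 1000 nM in a functional assay on MCF7 cells (Homo sapiens) for cytotoxicity, read by MTT assay, with a stated time of 72 h; on this read-out lower numbers stand for stronger inhibition and higher numbers for weaker inhibition. Among the measured compounds shown here, compound 2 `Cc1cc(CO)c2n1CSC2` gives 40900 nM in this assay, the highest of the two numbers; its only neighbour is compound 1, whose number lies far lower, beyond the scatter. Compound 3 `Cc1c(CO)c(CO)c2n1CSC2` has not been measured. It differs from compound 2 in one place: hydroxymethyl in place of hydrogen on an aromatic carbon, on an aromatic carbon of a five-membered aromatic ring with one nitrogen, part of a fused system of two rings, next to the ring atom that bears a hydroxymethyl group and next to the ring atom that bears a methyl group. Compound 3 therefore shares the pair of hydroxymethyl groups with compound 1, while compound 1 differs from it in a further place as well. Since compound 1 reaches 1000 nM, the step from compound 2 to compound 3 is expected to lower the number beyond the scatter, at an 8.2-fold lower number from compound 2 to compound 3 (0.91 log units; beyond the scatter). Compound 3 is estimated at 5000 nM, within a range from 1500 nM to 20000 nM.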

Compound 3, half-maximal inhibitory concentration: 22600 nM
The estimate for compound 3 lay 4.5-fold (0.66 log units) below the measured number, and the stated range ends below it.
By their numbers in this assay, from the lowest: compound 1; then compounds 3 and 2 (each within the scatter of the next).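

In this assay, hydroxymethyl in place of hydrogen on this aromatic carbon gives a 1.8-fold lower number from compound 2 to compound 3 (0.26 log units; within the scatter), so this change alone does not separate compound 3 from compound 2 beyond the usual scatter. The large step lies elsewhere: hydrogen in place of phenyl on the saturated ring carbon gives a 23-fold higher number from compound 1 to compound 3 (1.35 log units; beyond the scatter), which shows that the pair of hydroxymethyl groups does not by itself carry the number of compound 1. No measurement bears on the reason for either step.

On these data alone, it remains open whether hydroxymethyl at this aromatic carbon would matter as little on a core that carries the phenyl. Also open, as far as these compounds go, is how an amine, a carboxylic acid or a longer chain would read at that carbon, and how a methyl group would compare with phenyl on the saturated ring carbon.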